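Sulfonamide variation on the piperidine-ether series, agonist read-out

The source may report more compounds than this note shows. Statements on the series, on what has been measured and on what is new or still open speak of the compounds shown alone.

Compound 1 `CCS(=O)(=O)N[C@H]1CCCN(C(C)=O)[C@H]1CO[C@H]1CC[C@@H](C(C)C)CC1` carries an (ethylsulfonyl)amino group and in a functional assay on CHO-K1 cells for agonist activity at Orexin receptor type 2 (Homo sapiens), read by FLIPR and calcium flux (on this read-out higher numbers stand for an effect only at larger amounts of compound and lower numbers for an effect already at smaller amounts), compound 1 gives 270 nM. Compound 2 `CC(=O)N1CCC[C@H](NS(=O)(=O)C(C)C)[C@@H]1CO[C@H]1CC[C@@H](C(C)C)CC1` differs by methyl in place of hydrogen on a saturated chain carbon bound to a saturated chain carbon and a sulfonyl sulfur, and in this assay compound 2 gives 940 nM, so a 3.5-fold higher number from compound 1 to compound 2 (0.54 log units; beyond the scatter). Compound 3 `CC(=O)N1CCC[C@H](N(C)S(C)(=O)=O)[C@@H]1CO[C@H]1CC[C@@H](C(C)C)CC1` carries methyl(methylsulfonyl)amino in place of (ethylsulfonyl)amino on a saturated ring carbon. In this assay compound 3 gives only a limit, > 30000 nM, because of the limit of > 30000 nM in this assay, at which 1 of the 3 values shown sits. Compound 3 therefore stands at the weak end of the three, with an at least 110-fold higher number from compound 1 to compound 3 (2.04 log units; beyond the scatter) and an at least 31-fold higher number from compound 2 to compound 3 (1.50 log units; beyond the scatter).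

Compound 4 `CC(=O)N1CCC[C@H](NC(=O)O)[C@@H]1CO[C@H]1CC[C@@H](C(C)C)CC1` has not yet been measured; the change from compound 3 is carboxyamino in place of methyl(methylsulfonyl)amino on a saturated ring carbon. Within the data shown here, both measured steps into compound 3 were large and went toward higher numbers, and they bear on the loss of the hydrogen on the nitrogen, which compound 4 restores, while no measured step covers carboxyamino itself. Compound 4 is expected to give 10000 nM in this assay, within 1500 nM to 30000 nM, meaning an expected step of an at least 3.0-fold lower number from compound 3 to compound 4 (0.47 log units; beyond the scatter).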

Compound 4, half-maximal effective concentration: > 30000 nM
Compound 4 ended at the assay's limit (the forecaster's own chance of this, stated with the estimate: 50%); at least 3.0-fold (0.47 log units) between middle value and limit.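

Carboxy on the amine nitrogen gives a loss as large as can be read here, with an at least 31-fold higher number from compound 2 to compound 4 (1.50 log units; beyond the scatter) and an at least 110-fold higher number from compound 1 to compound 4 (2.04 log units; beyond the scatter), so the hydrogen on that nitrogen, present in compound 1, compound 2 and compound 4, is not enough on its own for a value inside the range of this assay. Compound 3 keeps a sulfonyl group and lacks that hydrogen, compound 4 keeps the hydrogen and lacks the sulfonyl group, and among the four compounds only compound 1 and compound 2, which have both, give values short of the limit. The step from compound 3 to compound 4 cannot be read, as both values are limits: the limit of > 30000 nM in this assay, at which 2 of the 4 values shown sit.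

Open, from the compounds shown here alone, is whether any group other than an alkylsulfonyl on the amine nitrogen can give a readable value, for instance an acetyl or a methoxycarbonyl in place of carboxy. Also open, going by these compounds, is how the methyl on the nitrogen of compound 3 and its shorter sulfonyl chain compare, as the measured compounds do not separate the two. The plain (methylsulfonyl)amino group would separate them.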